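Thiophene for furan at the saturated ring carbon

This account rests on a few compounds, and the source may have more. Where it says the series, first, only, none or still open, it means among the compounds named here.

compound 1 `CC1=C(C(=O)OC2CCC2)C(c2ccco2)NC(=O)N1`: 95.1 nM
compound 2 `CC1=C(C(=O)OC2CCC2)C(c2ccoc2)NC(=O)N1`: 307 nM

In an assay on membranes from HEK293 cells for displacement of a labelled ligand from adenosine receptor A2b (Homo sapiens), read by scintillation counting, with a stated time of 30 min (a lower number here means a stronger inhibitor, a higher number a weaker inhibitor), compound 1 gives 95.1 nM and compound 2 gives 307 nM. Within the data shown here, compound 2 stands highest of the two measured numbers, separated from compound 1 by the only measured step, a 3.2-fold higher number from compound 1 to compound 2 (0.51 log units; beyond the scatter). Compound 3 `CC1=C(C(=O)OC2CCC2)C(c2ccsc2)NC(=O)N1` differs from compound 2 by thiophen-3-yl in place of furan-3-yl on a saturated ring carbon. Among the measured compounds shown here, no measured step concerns an exchange of furan for thiophene, so in this assay no step beyond the scatter is expected, a 1.2-fold lower number from compound 2 to compound 3 (0.09 log units; within the scatter). Compound 3 is therefore estimated at about 250 nM, between 80 nM and 800 nM.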

Compound 3, inhibition constant: 405 nM
Estimate against measurement, compound 3: 1.6-fold (0.21 log units) below; measured number inside the range.
By their numbers in this assay, from the lowest: compound 1; then compounds 2 and 3 (each within the scatter of the next).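

In this assay, thiophen-3-yl and furan-3-yl cannot be told apart at this saturated ring carbon (a 1.3-fold higher number from compound 2 to compound 3 (0.12 log units; within the scatter)), so with the attachment point held, exchanging the ring oxygen for sulfur leaves the number within the scatter. Furan-2-yl in compound 1 remains the strongest of the three, and the gap to thiophen-3-yl is beyond the scatter (a 4.3-fold higher number from compound 1 to compound 3 (0.63 log units; beyond the scatter)). No evidence is available to explain these numbers.

The compounds shown leave open whether thiophen-2-yl would match furan-2-yl at this carbon. They also leave open how a phenyl ring or a propyl chain would read here.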